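Chain variation on the aromatic nitrogen of the shared core

This account rests on a few compounds, and the source may have more. Where it says the series, first, only, none or still open, it means among the compounds named here.

Measured so far:
- In a functional assay on HT-29 cells (Homo sapiens) for inhibition, read by luminescence and CellTiter-Glo, with a stated time of 24 h (on this read-out lower numbers stand for an effect already at smaller amounts and higher numbers for an effect only at larger amounts of compound), compound 1 `CC(C)n1nc(C(=O)N[C@H]2COc3ccccc3N(C)C2=S)nc1Cc1ccccc1` gives 360 nM.
- In this assay compound 2 `CN1C(=S)[C@@H](NC(=O)c2nc(Cc3ccccc3)n(CCCO)n2)COc2ccccc21` gives 209 nM.

Compound 1 stands highest of the two numbers; the nearest is compound 2, reached by a 1.7-fold lower number from compound 1 to compound 2 (0.24 log units; within the scatter), a step that swaps the isopropyl on the aromatic nitrogen for a chain carrying one hydrogen-bond acceptor.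

Compound 3 `CN1C(=S)[C@@H](NC(=O)c2nc(Cc3ccccc3)n(CCCCCC#N)n2)COc2ccccc21` is not yet measured. It differs from compound 1 by 5-cyanopentyl in place of isopropyl on an aromatic nitrogen. Among the compounds with values here, the only measured step that bears on this change is the one from compound 1 to compound 2, which stayed within the scatter. Compound 3 again replaces isopropyl by an open chain with a single hydrogen-bond acceptor, here longer by four heavy atoms than the chain in compound 2, so no step beyond the scatter in this assay is expected, and the estimated step is a 1.2-fold lower number from compound 1 to compound 3 (0.08 log units; within the scatter).

For compound 3 the expected value is 300 nM, with a range of 120 nM to 900 nM.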

Compound 3, half-maximal effective concentration: 3830 nM
The estimate for compound 3 lay 13-fold (1.11 log units) below the measured number, outside the stated range (above it).
By their numbers in this assay, from the lowest: compounds 2 and 1 (each within the scatter of the next); then compound 3.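

The aromatic nitrogen does not treat all open chains alike in this assay: 5-cyanopentyl in place of isopropyl gives an 11-fold higher number from compound 1 to compound 3 (1.03 log units; beyond the scatter), whereas the 3-hydroxypropyl chain of compound 2 stayed within the scatter of compound 1. Seen from compound 2, replacing the hydroxy with 2-cyanoethyl gives an 18-fold higher number from compound 2 to compound 3 (1.26 log units; beyond the scatter), so carrying a single hydrogen-bond acceptor on an open chain does not by itself keep the number near those of compound 1 and compound 2. Nothing available explains this rise.

Chain length and chain end change together in compound 3, so the compounds shown do not separate the contribution of each. As far as these compounds go, a 3-cyanopropyl chain and a 6-hydroxyhexyl chain would pull these two changes apart, and how either behaves at this nitrogen remains open.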